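The compounds below may be only part of what the source reports. "The series", "measured", "known", "first", "only" and "open" are said of these compounds alone.

Compound 1 `N#Cc1ccc(N2CCN(C(=S)SCc3ccc(C(=O)Nc4ccccc4N)cc3)CC2)cc1` carries a 4-cyanophenyl group on an amine nitrogen in a ring of the shared core; in a functional assay on MGC-803 cells (Homo sapiens) for antiproliferative activity, read by CCK-8 assay, with a stated time of 72 h, tested at 2 uM (a higher number here means a stronger effect of the compound at the concentration tested, a lower number a weaker effect), compound 1 gives 34.5%, the lowest of the three numbers in hand. Compound 2 `CN(Cc1ccncc1)C(=S)SCc1ccc(C(=O)Nc2ccccc2N)cc1` gives 38.1%, within the scatter of compound 1. Compound 3 `CN(Cc1cccnc1)C(=S)SCc1ccc(C(=O)Nc2ccccc2N)cc1` gives 45.9%, and the gap between compound 1 and compound 3 lies beyond the scatter. Among the measured compounds shown here, the only measured single-point step, a number 7.8 percentage points higher from compound 2 to compound 3 (within the scatter), concerns another part of the core. Compound 4 `Nc1ccccc1NC(=O)c1ccc(CSC(=S)N2CCN(Cc3ccccc3)CC2)cc1` differs from compound 1 by benzyl in place of 4-cyanophenyl on an amine nitrogen in a ring. For the measured compounds named here, no measured step touches this position, so no change beyond the scatter is expected, with a number 3.5 percentage points higher from compound 1 to compound 4 (within the scatter) as the expected step. Compound 4 is therefore estimated at 38%, in the range 25% to 52%.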

Compound 4, a percentage reported as inhibition, at one concentration (the size of the read-out at that concentration, not a potency): 18.1%
Beside the measured number, compound 4's estimate is 19.9 percentage points above it, outside the stated range (below it).
By their numbers in this assay, from the lowest: compound 4; then compounds 1, 2 and 3 (each within the scatter of the next, the first and the last beyond it).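

Among the compounds shown here, on an amine nitrogen in a ring of the shared core, the group is not interchangeable in this assay: benzyl in place of 4-cyanophenyl gives a number 16.4 percentage points lower from compound 1 to compound 4 (beyond the scatter), the first measured step at this position. The exchange removes the nitrile and adds a chain carbon in one move, so this step cannot separate the two changes. No data at hand account for the drop. Still open, on these data alone, is whether plain phenyl or 4-cyanobenzyl on this nitrogen would read closer to compound 1 or to compound 4.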